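Moving a Methoxy Group Around the Phenyl Ring

This account rests on a few compounds, and the source may have more. Where it says the series, first, only, none or still open, it means among the compounds named here.

Measured so far:
- compound 1, `Cc1ccc(Nc2nnc(Nc3nc(-c4ccc(Cl)cc4)cs3)s2)cc1`: 300 mg/kg
- compound 2, `COc1ccccc1Nc1nnc(Nc2nc(-c3ccc(Cl)cc3)cs2)s1`: 100 mg/kg

Both were tested in a functional assay on the whole organism (strain albino) with Mus musculus as the target, with a stated time of 4 h; a higher number here means that more compound is needed for the effect, a lower number that less compound is needed. Among the measured compounds shown here, compound 2 gives the lower of the two numbers; its only neighbour is compound 1, reached by the single measured step, a 3.0-fold lower number from compound 1 to compound 2 (0.48 log units; beyond the scatter), a modest gain. Compound 3, `COc1ccc(Nc2nnc(Nc3nc(-c4ccc(Cl)cc4)cs3)s2)cc1`, is the next candidate. It differs from compound 2 in one place: 4-methoxyphenyl in place of 2-methoxyphenyl on a nitrogen on an aromatic ring. For the measured compounds named here, no measured step moves a group from one position of this phenyl ring to another, so the one step at hand, which swaps a methyl for a methoxy on a nitrogen on an aromatic ring, bears only loosely on it. A shift no larger than that step is expected, most likely a small rise in the number. Compound 3 is therefore estimated at 200 mg/kg, within a range of 100 mg/kg to 400 mg/kg. That estimate amounts to a 2.0-fold higher number from compound 2 to compound 3 (0.30 log units; within the scatter).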

Compound 3, minimum effective dose: 300 mg/kg
Estimate against measurement, compound 3: 1.5-fold (0.18 log units) below; low and high end bracket the measured number.
By their numbers in this assay, from the lowest: compound 2; then compounds 1 and 3 (each within the scatter of the next).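

In this assay, the place of the methoxy group on this phenyl ring matters: 4-methoxyphenyl in place of 2-methoxyphenyl gives a 3.0-fold higher number from compound 2 to compound 3 (0.48 log units; beyond the scatter) and so undoes the earlier gain. The other new comparison shows no change at the digits printed from compound 1 to compound 3 (within the scatter) for methoxy in place of methyl on an aromatic carbon, so the methoxy group alone does not lower the number, and the lower number belongs to 2-methoxyphenyl in particular. Nothing measured on these compounds explains why the place of the group matters.

Going by these compounds, it remains open whether an ethoxy or a hydroxyl group in place of the methoxy of 2-methoxyphenyl would keep the lower number. A plain phenyl group on that nitrogen would also show how much any group on this ring contributes.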